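The source may hold more compounds than are shown below. What is called first, only, known or untested is meant among the compounds shown, and "the series" means these compounds.

Compound 1 `COc1cc(Cc2nc3c(N)nc(F)nc3n2CCOC(C)C)cc(OC)c1OC` gives 15800 nM in a functional assay on MCF7 cells (Homo sapiens) for antiproliferative activity; a higher number here means a weaker inhibitor, a lower number a stronger inhibitor. Compound 2 `C#CCCCn1c(Cc2cc(OC)c(OC)c(OC)c2)nc2c(N)nc(F)nc21` gives 11000 nM. Compound 3 `COc1cc(Cc2nc3c(N)ncnc3n2CCOC(C)C)cc(OC)c1OC` gives 38900 nM.

Among the three measured compounds, compound 3 has the highest number in this assay: the step of a 2.5-fold higher number from compound 1 to compound 3 (0.39 log units; beyond the scatter) separates it from compound 1, and its number lies further above that of compound 2. Compound 4 `CCCCCn1c(Cc2cc(OC)c(OC)c(OC)c2)nc2c(N)ncnc21` differs from compound 3 by propyl in place of isopropoxy on a saturated chain carbon, two bonds along the chain from an aromatic nitrogen. Going by the values given here, the one measured step at the same place, a 1.4-fold lower number from compound 1 to compound 2 (0.16 log units; within the scatter), replaced the same leaving group with another chain without a ring and stayed within the scatter. That step bears directly on this one, so a change of similar size, within the scatter and at most slightly towards a lower number, is expected here, a 1.3-fold lower number from compound 3 to compound 4 (0.11 log units; within the scatter). Compound 4 is accordingly estimated at 30000 nM, with a range from 12000 nM to 75000 nM.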

Compound 4, half-maximal inhibitory concentration: 61700 nM
Compound 4: middle estimate off by 2.1-fold (0.31 log units), on the low side; low and high end bracket the measured number.
By their numbers in this assay, from the lowest: compounds 2 and 1 (each within the scatter of the next); then compounds 3 and 4 (each within the scatter of the next).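

In this assay the exchange of isopropoxy for propyl gives a 1.6-fold higher number from compound 3 to compound 4 (0.20 log units; within the scatter) on the core carrying hydrogen in place of fluoro. Compounds 1 and 2 had shown such a swap within the scatter only on the fluoro core; now, at this place on the saturated chain, the chain can lose its oxygen on either core without a step beyond the scatter. No available evidence bears on this result. The compounds shown leave open whether an amine, a carboxylic acid or a longer chain at this place would move the number beyond the scatter.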